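The source may report more compounds than this note shows. Statements on the series, on what has been measured and on what is new or still open speak of the compounds shown alone.

Of the compounds shown here, three built on a shared core have been tested in a functional assay on the whole organism with Mus musculus as the target, with a stated time of 1 h, at a dose of 100 mg/kg by the intraperitoneal route; on this read-out higher numbers stand for more inhibition at the one dose given (going by the name of the read-out) and lower numbers for less inhibition. Compound 1 `c1ccc(COc2nc3ccccc3s2)cc1` gives 68.8%. Compound 2 `Fc1ccccc1COc1nc2ccccc2s1` gives 74.6%. Compound 3 `Fc1ccc(OCCOc2nc3ccccc3s2)cc1` gives 72.7%, and since all three numbers lie within the usual scatter of one another, none of them can be called stronger or weaker than the others. Compound 2 and compound 1 differ in one place, (hydrogen in place of fluoro on an aromatic carbon), and this change gave a number 5.8 percentage points lower from compound 2 to compound 1 (within the scatter). Compound 4 `c1ccc(OCCOc2nc3ccccc3s2)cc1` has not yet been measured; it differs from compound 3 by the same kind of change, (hydrogen in place of fluoro on an aromatic carbon). The two changes are not the same. In compound 2 the fluoro is ortho to a large group, whereas in compound 3 it is para to a large group. How the core of compound 3 differs from that of compound 2 is not broken down here. Going by the values given here, because the one comparable step measured so far was a number 5.8 percentage points lower from compound 2 to compound 1 (within the scatter), the step expected from compound 3 to compound 4 in this assay is estimated at a number 4.7 percentage points lower from compound 3 to compound 4 (within the scatter), a small one. Compound 4 is therefore expected to give about 68%, most likely between 55% and 80%.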

Compound 4, a percentage reported as inhibition, in the whole organism at one dose (the size of the read-out at that dose, not a potency): 7.31%
Estimate against measurement, compound 4: 60.7 percentage points above; the measured number lies below the stated range.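

Swapping fluoro for hydrogen on an aromatic carbon does not carry over from one core to another in this series with a fixed size: the same change on two cores in this assay, a number 5.8 percentage points lower (within the scatter) from compound 2 to compound 1 and a number 65.4 percentage points lower (beyond the scatter) from compound 3 to compound 4, 59.6 percentage points apart, beyond the scatter of two such steps In this assay, the fluoro para to a large group matters greatly on the core of compound 3, with a number 65.4 percentage points lower from compound 3 to compound 4 (beyond the scatter), whereas the step on the other core, a number 5.8 percentage points lower from compound 2 to compound 1 (within the scatter), cannot be told from the usual scatter. These two steps do not show why they differ, since the cores differ and the fluoro also sits in a different place on the ring in compound 2, and two steps cannot separate those influences or give a rule for further cores.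

The compounds shown leave open whether the large step belongs to fluoro alone or whether a chloro or methoxy group in the same place would also keep the number of compound 3 high. They also leave open how the step would behave on a core with a longer chain between the ring and the oxygen.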